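This account rests on a few compounds, and the source may have more. Where it says the series, first, only, none or still open, it means among the compounds named here.

Compound 3 `O=C(Nc1ccc(Cl)c(-c2nnc3c(Cl)cccn23)c1)c1ccc(Cl)cc1Cl` is one of three compounds built on a shared core and tested in a functional assay on HeLa cells (Homo sapiens) for antiproliferative activity, read by MTT assay, with a stated time of 72 h; on this read-out higher numbers stand for weaker inhibition and lower numbers for stronger inhibition. In this assay compound 3 gives > 100000 nM, which is a limit of the assay and not a number. Compound 1 `O=C(Nc1ccc(Cl)c(-c2nnc3c(Cl)cccn23)c1)c1ccc(F)cc1Cl` also gives the limit of > 100000 nM in this assay. Compound 2 `Cc1nc(C(=O)Nc2ccc(Cl)c(-c3nnc4c(Cl)cccn34)c2)cs1` gives 79800 nM in this assay. Two of the three values thus sit at the limit of > 100000 nM in this assay, at which 2 of the 3 values shown sit, and compound 3 stands there. Compound 4 `O=C(Nc1ccc(Cl)c(-c2nnc3c(Cl)cccn23)c1)c1cccnc1Cl` carries 2-chloropyridin-3-yl in place of 2,4-dichlorophenyl on a carbonyl carbon. The steps that also swap the group on the carbonyl carbon are an at least 1.2-fold lower number from compound 1 to compound 2 (0.09 log units; that floor lies within the scatter) and an at least 1.2-fold higher number from compound 2 to compound 3 (0.09 log units; that floor lies within the scatter), neither readable beyond the scatter. No step beyond the scatter is therefore expected in this assay. Compound 4 is expected to give 100000 nM, between 40000 nM and 300000 nM. The expected step is a number no higher from compound 3 to compound 4 (the limit leaves the size open).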

Compound 4, half-maximal inhibitory concentration: 87500 nM
Compound 4: the middle estimate sits 1.1-fold (0.06 log units) above what was measured; the measured number falls inside the stated range.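

In this assay, 2-chloropyridin-3-yl on this carbonyl carbon gives an at least 1.1-fold lower number from compound 3 to compound 4 (0.05 log units; that floor lies within the scatter) and an at least 1.1-fold lower number from compound 1 to compound 4 (0.05 log units; that floor lies within the scatter). Set against 2-methyl-1,3-thiazol-4-yl, it gives a 1.1-fold higher number from compound 2 to compound 4 (0.04 log units; within the scatter). Changing the carbon-only ring to one with a ring nitrogen therefore brings no step beyond the scatter, and this position has yet to show a readable effect on the number.

From the compounds shown here alone, whether a ring bearing an amine or a carboxylic acid would bring the number down stays open. The true sizes of the steps from compound 1 and compound 3 also stay open, as both compounds sit at a limit of the assay: the limit of > 100000 nM in this assay, at which 2 of the 4 values shown sit.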